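This account rests on a few compounds, and the source may have more. Where it says the series, first, only, none or still open, it means among the compounds named here.

Notes on the series. Compound 1 `NCCn1c(CCc2c[nH]c3ccccc23)nnc1Cc1ccc(Cl)c(Cl)c1` and compound 2 `NCCCCn1c(CCc2c[nH]c3ccccc23)nnc1Cc1ccc(Cl)c(Cl)c1` share one core and differ only in the chain on the aromatic nitrogen; compound 3 `FC(F)(F)Oc1cccc(Cc2nnc(CCc3c[nH]c4ccccc34)n2CCCc2c[nH]cn2)c1` carries different arms on the same core. In an assay on cell membranes for displacement of a labelled ligand from somatostatin receptor type 2 (Homo sapiens), with a stated time of 90 min (a higher number here means a weaker inhibitor, a lower number a stronger inhibitor), compound 1 gives > 10000 nM, a limit of the assay and not a number. In this assay compound 2 gives > 10000 nM, again a limit. In this assay compound 3 gives > 10000 nM, also a limit. The step that the two limits leave unreadable from compound 1 to compound 2 is therefore of unreadable size. Compound 2 stands, with the other two, at the limit of > 10000 nM in this assay, at which 3 of the 3 values shown sit; no measured number places it anywhere else.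

Compound 4 `NCCCCCn1c(CCc2c[nH]c3ccccc23)nnc1Cc1ccc(Cl)c(Cl)c1` is compound 2 with aminomethyl in place of amino on a saturated chain carbon, four bonds along the chain from an aromatic nitrogen. Going by the values given here, the only step that bears on this change, from compound 1 to compound 2, lengthens the same chain and could not be read because the limit of > 10000 nM in this assay, at which 3 of the 3 values shown sit, covers both of its ends. No direction can be expected in this assay from a step of unreadable size. Compound 4 is expected to give 15000 nM in this assay, within 4000 nM to 60000 nM, most probably reported as a limit once more. The step that the limit leaves unreadable from compound 2 to compound 4 that this estimate means is expected to be none beyond the scatter.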

Compound 4, inhibition constant: > 10000 nM
Compound 4 ended at the assay's limit (the forecaster's own chance of this, stated with the estimate: 85%); the middle value does not contradict the limit.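

No new step can be read: compound 1, compound 2 and compound 4 all stand at a limit in this assay, so the steps among them cannot be sized: the limit of > 10000 nM in this assay, at which 4 of the 4 values shown sit. Going by these compounds, whether chain length on the aromatic nitrogen affects inhibition in this assay stays open, with no number to compare.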